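Benzyloxycarbonyl to carboxy: the next step in the series

A few compounds are considered here, and "the series" means these few. Any claim that something is new, unique, unknown or untested is made for them only; others in the source may bear on it.

In a functional assay on MCF7 cells (Homo sapiens) for cytotoxicity, read by colorimetric assay and MTT assay (a higher number here means a weaker inhibitor, a lower number a stronger inhibitor), compound 1 (`COc1ccc(-c2cc3c(OC)cc(OC)cc3n(CC#N)c2=O)cc1`) gives 10000 nM. Compound 2 (`COc1ccc(-c2cc3c(OC)cc(OC)cc3n(CC(=O)OCc3ccccc3)c2=O)cc1`) gives 10000 nM, level with compound 1, its nearest neighbour on these numbers. Among the compounds with values here, the only measured step reads no change at the digits printed from compound 1 to compound 2 (within the scatter), with benzyloxycarbonyl in place of cyano on a saturated chain carbon bound to an aromatic nitrogen.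

Compound 3 (`COc1ccc(-c2cc3c(OC)cc(OC)cc3n(CC(=O)O)c2=O)cc1`) is still unmeasured. Its difference from compound 2 is hydrogen in place of benzyl on an oxygen next to a carbonyl group, which is hydrogen in place of benzyl on an oxygen next to a carbonyl group, or benzyloxycarbonyl to carboxy when cut one bond further out.

The measured step bears on this change only loosely. Within the data shown here, it alters the same side chain and shows no size at all, but no measured compound carries a carboxy group, so the evidence is thin. On that basis, no step beyond the scatter is expected in this assay, and no direction is favoured.

The expected step is no change at the digits printed from compound 2 to compound 3 (within the scatter). For compound 3 the estimated value is 10000 nM, with an expected range from 4000 nM to 20000 nM.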

Compound 3, half-maximal inhibitory concentration: 10000 nM
Estimate against measurement, compound 3: no gap at the digits printed; the range from low to high includes it.
By their numbers in this assay, from the lowest: compounds 1, 2 and 3 (each within the scatter of the next).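

Within the data shown here, compound 3 is the first member of the series with a carboxy group on the side chain, and in this assay it gives 10000 nM. Taking away the benzyl group, with its 7 heavy atoms and its six-membered aromatic ring, leaves the reading as it stood: the step is no change at the digits printed from compound 2 to compound 3 (within the scatter) for hydrogen in place of benzyl on an oxygen next to a carbonyl group. The comparison with the nitrile end gives the same picture, no change at the digits printed from compound 1 to compound 3 (within the scatter) for carboxy in place of cyano on a saturated chain carbon bound to an aromatic nitrogen, so cyano, benzyloxycarbonyl and carboxy all read alike at this place in this assay. No information is available that explains this agreement.

Among these compounds, with all three compounds level, the series so far holds no step beyond the scatter, and no group at this place is yet tied to any shift in the reading. Open, on these data alone, are a primary amide or an amine at the end of this side chain, a longer chain carrying the carboxy group, and any change to the methoxy groups of the shared core.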